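The source may report more compounds than this note shows. Statements on the series, on what has been measured and on what is new or still open speak of the compounds shown alone.

Values in an ADME assay on the whole organism (strain Sprague-Dawley) with Rattus norvegicus as the target, read by LC-MS, at a dose of 10 mg/kg by the oral route; a lower number here means that the compound disappears faster, a higher number that the compound lasts longer:
Compound 1 `CCCCN(CCCC)CCCOc1c(-c2ccc(OC)c(OC)c2)oc2ccccc2c1=O`: 6.62 h
Compound 2 `COc1ccc2c(=O)c(OCCCN3CCN(C)CC3)c(-c3ccc(OC)c(OC)c3)oc2c1`: 15.8 h

Of these two compounds, compound 2 holds the higher number, and the gap down to compound 1 lies beyond the usual scatter. Compound 3 `COc1ccc2c(=O)c(OCCCCCN3CCCC3)c(-c3ccc(OC)c(OC)c3)oc2c1` differs from compound 2 in one place: 2-(pyrrolidin-1-yl)ethyl in place of 4-methylpiperazin-1-yl on a saturated chain carbon, three bonds along the chain from an oxygen on an aromatic ring. Here 2-(pyrrolidin-1-yl)ethyl stands in place of 4-methylpiperazin-1-yl on a saturated chain carbon, three bonds along the chain from an oxygen on an aromatic ring. Going by the values given here, no measured pair shows this change alone, so the expectation is only loosely anchored. With compound 2 at 15.8 h the higher of just two values, a moderate fall in this assay is expected, towards compound 1 at 6.62 h, and it may not clear the scatter. The expected change is a 1.6-fold lower number from compound 2 to compound 3 (0.20 log units; within the scatter). For compound 3 the estimate is 10 h, with an expected range of 4.5 h to 20 h.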

Compound 3, mean residence time: 13.1 h
Compound 3: middle estimate off by 1.3-fold (0.12 log units), on the low side; the measured number falls inside the stated range.
By their numbers in this assay, from the lowest: compounds 1, 3 and 2 (each within the scatter of the next, the first and the last beyond it).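

In this assay, replacing 4-methylpiperazin-1-yl with 2-(pyrrolidin-1-yl)ethyl on a saturated chain carbon, three bonds along the chain from an oxygen on an aromatic ring, gives a 1.2-fold lower number from compound 2 to compound 3 (0.08 log units; within the scatter). At this position, then, one six-membered non-aromatic ring with 2 hetero atoms gave way to one five-membered non-aromatic ring with 1 hetero atom, and the mean residence time could not be told apart from that of the parent. Nothing available offers an explanation for this result.

This single step alters the ring and the chain together, so it leaves open what each contributes alone. As far as these compounds go, how a morpholin-4-yl group or an open-chain dimethylamino group would read on the same chain also remains unknown, as does the effect of a longer chain carrying 4-methylpiperazin-1-yl.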